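This account rests on a few compounds, and the source may have more. Where it says the series, first, only, none or still open, it means among the compounds named here.

Compound 1 `CC1(C#Cc2c(Cl)c3c(Cl)cc(C(N)=O)nc3n2[C@H]2CCCNC2)COC1`: 119 nM in a functional assay on KG-1 cells (Homo sapiens) for antiproliferative activity; a higher number here means that more compound is needed for the effect, a lower number that less compound is needed.
Compound 2 `CC(O)CC#Cc1c(Cl)c2c(Cl)cc(C(N)=O)nc2n1[C@H]1CCCNC1`: 48 nM in this assay.

Compound 2 stands lowest of the two numbers in this assay; its nearest neighbour is compound 1, which lies at 119 nM. Compound 3 `COCCC#Cc1c(Cl)c2c(Cl)cc(C(N)=O)nc2n1[C@H]1CCCNC1` differs from compound 2 by methoxymethyl in place of 1-hydroxyethyl on a saturated chain carbon bound to a triple-bonded carbon. Among the compounds with values here, the only measured step, a 2.5-fold lower number from compound 1 to compound 2 (0.39 log units; beyond the scatter), also alters the group on the triple-bonded chain, but not in the same way, so it bears on the change only loosely. Compound 3 is therefore expected to lie near compound 2, with a step of a 1.5-fold higher number from compound 2 to compound 3 (0.16 log units; within the scatter) in this assay, giving an estimate of 70 nM (range 30 nM to 170 nM).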

Compound 3, half-maximal effective concentration in the KG-1 assay: 39 nM
Compound 3: middle estimate off by 1.8-fold (0.25 log units), on the high side; the measured number falls inside the stated range.
By their numbers in the KG-1 assay, from the lowest: compounds 3 and 2 (each within the scatter of the next); then compound 1.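

Methoxymethyl in place of 1-hydroxyethyl on this saturated chain carbon, which takes away that group's hydrogen-bond donor, makes no difference beyond the scatter in the KG-1 assay, with a 1.2-fold lower number from compound 2 to compound 3 (0.09 log units; within the scatter). Against 3-methyloxetan-3-yl, the 2-methoxyethyl group gives a 3.1-fold lower number from compound 1 to compound 3 (0.48 log units; beyond the scatter), as the 2-hydroxypropyl group did. The same change does show in a physicochemical assay for solubility, measured as thermodynamic solubility, at pH 7.4 (a higher number here means a more soluble compound, a lower number a less soluble compound), where swapping the hydroxyl-bearing group for the ether costs solubility: the measured solubility of compound 2, 760000 nM, and of compound 3, 86000 nM, an 8.8-fold lower number (0.95 log units; beyond the scatter)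

This single pair cannot separate the loss of the donor from the shift of the oxygen along the chain. Going by these compounds, it remains open whether an amine or a carboxylic acid at this place would hold the number in the KG-1 assay while matching compound 2 at the physicochemical assay 760000 nM rather than compound 3 at 86000 nM.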